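Inversion of one ring stereocentre in the short-linker pair

The source may report more compounds than this note shows. Statements on the series, on what has been measured and on what is new or still open speak of the compounds shown alone.

Working notes. The two measured compounds were tested in an assay on membranes from Cerebral cortex for binding affinity to Adrenergic receptor alpha-1 (Rattus norvegicus); on this read-out lower numbers stand for stronger inhibition and higher numbers for weaker inhibition. Compound 1 `C[C@@H]1CN(c2cccc3ccccc23)CCN1CN1CC(=O)N2CCC[C@@H]2C1=O` sits at the limit of this assay, giving > 1000 nM, so only a boundary is known for it and no number. For the measured compounds named here, compound 2 `O=C1C2CCCN2C(=O)CN1CCCCN1CCN(c2cccc3ccccc23)CC1`, the other measured member of the series, gives 8 nM in this assay; the two values show one compound at the boundary and one clearly inside the measurable range, and nothing more can be said of that pair, as no single-point step joins them.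

Compound 3 `C[C@@H]1CN(c2cccc3ccccc23)CCN1CN1CC(=O)N2CCC[C@H]2C1=O` has not yet been measured in this assay. It differs from compound 1 as follows: the two compounds have the same atoms and bonds and differ only in configuration as drawn: 1 of 2 stereo elements differ; a stereocentre at a saturated ring carbon is drawn R in compound 1 and S in compound 3. Going by the values given here, no measured step between neighbouring compounds exists, so the size of such a change cannot be read from a measured pair. Among the compounds with values here, the only anchor is compound 1 at the limit (the limit of > 1000 nM in this assay, at which 1 of the 2 values shown sits). For compound 3 a step of an at least 1.2-fold lower number from compound 1 to compound 3 (0.09 log units; that floor lies within the scatter) toward stronger binding is expected, though a result that again reaches only the limit would not be surprising. Compound 3 is therefore estimated at 800 nM, with a range from 100 nM to 5000 nM.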

Compound 3, inhibition constant: > 1000 nM
Compound 3 ended at the assay's limit; the forecaster's own chance of this, stated with the estimate: 45%; middle value at least 1.2-fold (0.09 log units) away from the limit.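

No step from compound 1 to compound 3 can be read in this assay, as both compounds give only a limit and no number: the limit of > 1000 nM in this assay, at which 2 of the 3 values shown sit.

The compounds shown leave open whether the configuration at the saturated ring carbon, drawn R in compound 1 and S in compound 3, has any bearing on binding in this assay.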